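Amide nitrogen substituent variation on a shared core

The compounds below may be only part of what the source reports. "The series", "measured", "known", "first", "only" and "open" are said of these compounds alone.

Measured so far in a functional assay on PC-3 cells (Homo sapiens) for inhibition, read by sulforhodamine B assay, with a stated time of 72 h; on this read-out higher numbers stand for weaker inhibition and lower numbers for stronger inhibition:
compound 1 `Nc1sc(-c2ccc(Cl)cc2)c(-c2ccc(Cl)cc2)c1C(=O)NC1CCCC1` gives 21200 nM
compound 2 `Nc1sc(-c2ccc(Cl)cc2)c(-c2ccc(Cl)cc2)c1C(=O)NC1CCC1` gives 24800 nM
compound 3 `CC(C)CNC(=O)c1c(N)sc(-c2ccc(Cl)cc2)c1-c1ccc(Cl)cc1` gives 13200 nM

Compound 3 holds the lowest of the three numbers, yet every step to it lies within the scatter: a 1.6-fold lower number from compound 1 to compound 3 (0.21 log units; within the scatter) and a 1.9-fold lower number from compound 2 to compound 3 (0.27 log units; within the scatter); likewise a 1.2-fold higher number from compound 1 to compound 2 (0.07 log units; within the scatter). Compound 4 `Nc1sc(-c2ccc(Cl)cc2)c(-c2ccc(Cl)cc2)c1C(=O)Nc1ccccc1` differs from compound 3 in one place: phenyl in place of isobutyl on an amide-type nitrogen. Going by the values given here, no measured step exchanges a saturated group for an aromatic ring on this nitrogen; the three measured steps, all among saturated groups there, stayed within the scatter. On that basis the step of a 1.1-fold lower number from compound 3 to compound 4 (0.04 log units; within the scatter) is expected to stay within the scatter too, with no direction claimed. Compound 4 is therefore estimated at 12000 nM, in the range 4000 nM to 40000 nM.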

Compound 4, half-maximal inhibitory concentration: > 50000 nM
Compound 4 ended at the assay's limit; the forecaster's own chance of this, stated with the estimate: 15%; middle value at least 4.1-fold (0.61 log units) away from the limit.
By their numbers in this assay, from the lowest: compounds 3, 1 and 2 (each within the scatter of the next). At a limit, above all of these: compound 4.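

Compound 4 carries a limit of the assay, not a number: the limit of > 50000 nM in this assay, at which 1 of the 4 values shown sits. Going by these compounds alone, on this amide-type nitrogen, phenyl gives the first steps beyond the scatter, with an at least 3.7-fold higher number from compound 3 to compound 4 (0.57 log units; beyond the scatter) and an at least 2.3-fold higher number from compound 1 to compound 4 (0.37 log units; beyond the scatter), while exchanges among the saturated groups stayed within it. The remaining step, an at least 2.0-fold higher number from compound 2 to compound 4 (0.30 log units; that floor lies within the scatter), does not clear the scatter on its floor alone.

As far as these compounds go, how far the true value of compound 4 lies past the limit stays open. Also open, from the compounds shown here alone, is whether the shift follows any aromatic ring on this nitrogen or phenyl alone; a benzyl group or a pyridine ring there would bear on this.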